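The source may hold more compounds than are shown below. What is called first, only, known or untested is meant among the compounds shown, and "the series" means these compounds.

Compound 1 `NCCOCCOc1ccc([C@H]2CC[C@]3(CC2)OOC2(O3)C3CC4CC(C3)CC2C4)cc1`: < 7 mL.min-1.g-1
Compound 2 `CS(=O)(=O)N1CCN(CCCOc2ccc([C@H]3CC[C@]4(CC3)OOC3(O4)C4CC5CC(C4)CC3C5)cc2)CC1`: 68 mL.min-1.g-1

In an ADME assay on microsomes from liver (Homo sapiens) for metabolic stability, read by LC-MS, tested at 1 uM (a higher number here means faster removal of the compound, a lower number slower removal), compound 1 reaches only a limit of the assay, < 7 mL.min-1.g-1. In this assay compound 2 gives 68 mL.min-1.g-1. Going by the values given here, the single measured step, an at least 9.7-fold higher number from compound 1 to compound 2 (0.98 log units; beyond the scatter), shows that altering the chain at this position can shift the number well beyond the scatter. Compound 3 `CC1(C)CC(O)(COc2ccc([C@H]3CC[C@]4(CC3)OOC3(O4)C4CC5CC(C4)CC3C5)cc2)CC(C)(C)N1` differs from compound 1 by 4-hydroxy-2,2,6,6-tetramethylpiperidin-4-yl in place of (2-aminoethoxy)methyl on a saturated chain carbon bound to an oxygen on an aromatic ring. Because compound 1 sits at the limit (the limit of < 7 mL.min-1.g-1 in this assay, at which 1 of the 2 values shown sits), the true size of any step is uncertain; a modest rise, an at least 2.1-fold higher number from compound 1 to compound 3 (0.33 log units; beyond the scatter), is expected. Compound 3 is therefore estimated at 15 mL.min-1.g-1, between 5 mL.min-1.g-1 and 45 mL.min-1.g-1.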

Compound 3, intrinsic clearance in microsomes: 14 mL.min-1.g-1
The estimate for compound 3 lay 1.1-fold (0.03 log units) above the measured number; low and high end bracket the measured number.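

Replacing 2-(4-(methylsulfonyl)piperazin-1-yl)ethyl with 4-hydroxy-2,2,6,6-tetramethylpiperidin-4-yl in this assay gives a 4.9-fold lower number from compound 2 to compound 3 (0.69 log units; beyond the scatter), so the number at this position depends on which ring-bearing group sits there, not merely on a ring being present. The other step, an at least 2.0-fold higher number from compound 1 to compound 3 (0.30 log units; that floor lies within the scatter), has a floor within the scatter, so it does not establish a real difference between these two compounds. Compound 1 stands at a limit of the assay, not at an exact number: the limit of < 7 mL.min-1.g-1 in this assay, at which 1 of the 3 values shown sits.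

Still open, from the compounds shown here alone, is where a plain piperidin-4-yl group, without the methyl groups and the hydroxy group, would fall relative to compound 2 and compound 3.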